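Methoxy in place of chloro, para instead of meta

The source may hold more compounds than are shown below. What is called first, only, known or untested is meant among the compounds shown, and "the series" means these compounds.

Three compounds of the series share one core and differ only in the group on the aromatic ring that hangs from the ether oxygen. Compound 1 `Cc1cc(COc2cccc(Cl)c2)nc(-c2ccccn2)n1` gives 398 nM in a functional assay on cells for antagonist activity at Free fatty acid receptor 1 (Homo sapiens), read by TR-FRET and inositol phosphate accumulation, with a stated time of 2 h; on this read-out lower numbers stand for stronger inhibition and higher numbers for weaker inhibition. Compound 2 `Cc1cc(COc2ccc(Cl)cc2)nc(-c2ccccn2)n1` gives 251 nM in this assay, and the step of a 1.6-fold lower number from compound 1 to compound 2 (0.20 log units; within the scatter) comes from the change (4-chlorophenyl in place of 3-chlorophenyl on an oxygen on a saturated carbon). Compound 3 `COc1cccc(OCc2cc(C)nc(-c3ccccn3)n2)c1` gives 2000 nM in this assay; the step of a 5.0-fold higher number from compound 1 to compound 3 (0.70 log units; beyond the scatter) comes from the change (methoxy in place of chloro on an aromatic carbon), and it is the one clear movement among the three values. Compound 2 and compound 3 are not joined by a single change; their values simply stand well apart.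

Compound 4 `COc1ccc(OCc2cc(C)nc(-c3ccccn3)n2)cc1` is not yet measured. It differs from compound 2 by methoxy in place of chloro on an aromatic carbon. This is the same kind of change as that from compound 1 to compound 3, but not the same: there the methoxy sits meta to a large group, here para to a large group. The change has been seen once so far, and only in the meta arrangement.

Among the compounds with values here, for compound 4 the step from compound 2 is expected to be about a 5.0-fold higher number from compound 2 to compound 4 (0.70 log units; beyond the scatter) in this assay, a weakening of similar size to the earlier one, because a 5.0-fold higher number from compound 1 to compound 3 (0.70 log units; beyond the scatter) is the only guide available and the two cores are identical. The estimate for compound 4 is therefore 1250 nM, with a range from 500 nM to 3200 nM to allow for the different position of the methoxy.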

Compound 4, half-maximal inhibitory concentration: 7940 nM
Estimate against measurement, compound 4: 6.4-fold (0.80 log units) below; measured number outside the range, above it.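

In this assay, methoxy in place of chloro, para to a large group, gives a 32-fold higher number from compound 2 to compound 4 (1.50 log units; beyond the scatter); the direction matches the earlier step but the size does not: the same change on two cores in this assay, a 5.0-fold higher number (0.70 log units; beyond the scatter) from compound 1 to compound 3 and a 32-fold higher number (1.50 log units; beyond the scatter) from compound 2 to compound 4, 6.3-fold (0.80 log units) apart, beyond the scatter of two such steps

The two chloro compounds lie within the scatter of each other, at a 1.6-fold lower number from compound 1 to compound 2 (0.20 log units; within the scatter), so the separation appears only on the methoxy side, where compound 3 gives 2000 nM and compound 4 gives 7940 nM. Within the data shown here, in these two pairs, a step measured on one core gives the direction of the change on the other, but not a reliable size, and with only one pair for each arrangement this is no general rule for the series and shows nothing about the cause of the difference.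

The compounds shown leave open whether the uneven weakening belongs to methoxy alone or would return with another group in place of chloro, such as an amine or a carboxylic acid. As far as these compounds go, it also remains open whether the two arrangements would stay this far apart with a longer chain in place of methoxy.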